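Urea linkage fixed, methoxy added on the anilino ring

The source may report more compounds than this note shows. Statements on the series, on what has been measured and on what is new or still open speak of the compounds shown alone.

Three compounds share one core and differ only in what sits on the carbonyl carbon. Compound 1 `CN(C(=O)c1ccccc1)c1ccc2[nH]c(-c3n[nH]c4ccccc34)cc2n1` carries a phenyl there and gives 4850 nM in a functional assay on HL-60 cells (Homo sapiens) for antiproliferative activity, read by MTT assay, with a stated time of 72 h; a lower number here means a stronger inhibitor, a higher number a weaker inhibitor. Compound 2 `CN(C(=O)c1ccco1)c1ccc2[nH]c(-c3n[nH]c4ccccc34)cc2n1` carries a furan-2-yl and gives 4540 nM in this assay; the step of a 1.1-fold lower number from compound 1 to compound 2 (0.03 log units; within the scatter) shows the two aryl groups are interchangeable. Compound 3 `CN(C(=O)Nc1ccccc1)c1ccc2[nH]c(-c3n[nH]c4ccccc34)cc2n1` carries an anilino instead and gives 8.3 nM in this assay, the lowest of the three numbers, with the steps of a 580-fold lower number from compound 1 to compound 3 (2.77 log units; beyond the scatter) and a 550-fold lower number from compound 2 to compound 3 (2.74 log units; beyond the scatter) marking the urea linkage as what separates it from the other two.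

Compound 4 `COc1ccc(NC(=O)N(C)c2ccc3[nH]c(-c4n[nH]c5ccccc45)cc3n2)cc1` keeps that urea and changes only (methoxy in place of hydrogen on an aromatic carbon). Among the measured compounds shown here, none of the measured steps touches the anilino ring itself; they speak only to the linkage, which compound 4 retains, and to the aryl swap, which changed nothing. The step from compound 3 to compound 4 is therefore expected to be small, a 1.0-fold lower number from compound 3 to compound 4 (0.02 log units; within the scatter), with no direction that can be claimed beyond the scatter. Compound 4 is estimated to give 8 nM in this assay, within a range from 3 nM to 25 nM.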

Compound 4, half-maximal inhibitory concentration: 7.9 nM
Compound 4: middle estimate off by 1.0-fold (0.01 log units), on the high side, within the range that was stated.
By their numbers in this assay, from the lowest: compounds 4 and 3 (each within the scatter of the next); then compounds 2 and 1 (each within the scatter of the next).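

In this assay, among the compounds shown here, the methoxy on an aromatic carbon of the anilino ring, para to a large group, gives the first reading of this ring: a 1.1-fold lower number from compound 3 to compound 4 (0.02 log units; within the scatter), so the substitution leaves the number unmoved within the scatter. The linkage result also holds with the substituted ring, since a 570-fold lower number from compound 2 to compound 4 (2.76 log units; beyond the scatter) and a 610-fold lower number from compound 1 to compound 4 (2.79 log units; beyond the scatter) are both large and beyond the scatter, so (4-methoxyphenyl)amino on the carbonyl carbon stands apart from furan-2-yl and phenyl just as anilino does. The data shown offer no independent evidence on why this methoxy leaves the number unchanged or why the urea compounds stand so far from the other two.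

As far as these compounds go, one group at one place cannot describe the whole ring, so it remains open whether a chlorine, a nitrile, a carboxylic acid or a dimethylamino group at this position would behave as methoxy does, and whether methoxy would do the same on another carbon of the ring. From the compounds shown here alone, it is also open whether the aromatic ring itself is needed on the urea, or whether a cyclohexyl group or a longer alkyl chain could take its place.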